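Swapping Selenium for Sulfur in a Cytotoxicity Series

The compounds below may be only part of what the source reports. "The series", "measured", "known", "first", "only" and "open" are said of these compounds alone.

Of the compounds shown here, three built on one shared core have been tested in a functional assay on K562 cells (Homo sapiens) for cytotoxicity, read by MTT assay, with a stated time of 72 h; a lower number here means that less compound is tolerated, a higher number that more compound is tolerated. Compound 1 `CS/C(=N\C(=O)c1ccno1)NC(=O)c1ccno1` reaches only the limit of the assay, with compound 1 giving > 100000 nM. Compound 3 `CS/C(=N\C(=O)c1ccco1)NC(=O)c1ccco1` likewise gives only a limit, compound 3 recording > 100000 nM. Among the compounds with values here, compound 2 `C[Se]/C(=N\C(=O)c1sccc1Cl)NC(=O)c1sccc1Cl` is the one member with a real number: in this assay compound 2 gives 90000 nM. Within the data shown here, compound 2 therefore stands as the only measured value among the three, while the other two sit at the limit of > 100000 nM in this assay, at which 2 of the 3 values shown sit, so no ordering among them can be drawn.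

Compound 4 `CS/C(=N\C(=O)c1sccc1Cl)NC(=O)c1sccc1Cl` has not yet been measured. It differs from compound 2 in one place: a group of 2 heavy atoms (1 carbon, 1 sulfur; no ring) in place of a group of 2 heavy atoms (1 carbon, 1 selenium; no ring), on a carbon with a double bond to nitrogen. No pair of measured compounds differs in only this way, so the size of this step is not known from the numbers shown. Compound 1 already carries a methylsulfanyl group and gave only a limit, > 100000 nM. Compound 3 carries the same group and also gave only a limit, > 100000 nM. On that basis the step of a 1.7-fold higher number from compound 2 to compound 4 (0.22 log units; within the scatter) is expected to lie toward a higher number, likely within the scatter. Compound 4 is estimated at 150000 nM, within a range from 60000 nM to 400000 nM, with a real chance that the assay reports only a limit.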

Compound 4, concentration lethal to 50% of the cells: > 100000 nM
Compound 4 ended at the assay's limit; the forecaster's own chance of this, stated with the estimate: 65%; the middle value lies beyond the limit too.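

In this assay, within the data shown here, the exchange of the selenium-bearing group for methylsulfanyl can now be read directly for the first time, on a carbon with a double bond to nitrogen whose other neighbours are amide-type nitrogens: this single change gives an at least 1.1-fold higher number from compound 2 to compound 4 (0.04 log units; that floor lies within the scatter). With everything else in the pair held the same, this step offers no sign that methylsulfanyl brings a lower number than the selenium-bearing group, but its floor is too small to show that the change has any real effect. Among these compounds, compound 2 remains the only member of the series with a real number, and the sulfur compounds now all share one ceiling: the limit of > 100000 nM in this assay, at which 3 of the 4 values shown sit.

Going by these compounds, since compound 4 gives only a limit, the true size of the step stays open, and it could lie within the scatter or well beyond it. The compounds shown also leave open how this position would respond to a different kind of group, such as an amine or a longer chain like ethylsulfanyl, and whether any such group would bring a number clearly lower than that of compound 2.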